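From 4-fluorophenyl to 3-hydroxyphenyl on the shared core

The source may hold more compounds than are shown below. What is called first, only, known or untested is meant among the compounds shown, and "the series" means these compounds.

In a functional assay on MCF7 cells (Homo sapiens) for inhibition, read by MTT assay, with a stated time of 72 h (a lower number here means a stronger inhibitor, a higher number a weaker inhibitor), compound 1 (`COc1cc(NC(C)CCCNC(=O)Nc2cccc(F)c2)c2ncccc2c1`) gives 18000 nM and compound 2 (`COc1cc(NC(C)CCCNC(=O)Nc2cccc(Cl)c2)c2ncccc2c1`) gives 11000 nM on the same core. Compound 3 (`COc1cc(NC(C)CCCNC(=O)Nc2ccc(F)cc2)c2ncccc2c1`) gives 26000 nM in this series. Its two steps are a 1.4-fold higher number from compound 1 to compound 3 (0.16 log units; within the scatter) and a 2.4-fold higher number from compound 2 to compound 3 (0.37 log units; beyond the scatter) in size. Compound 4 (`COc1cc(NC(C)CCCNC(=O)Nc2cccc(O)c2)c2ncccc2c1`) carries 3-hydroxyphenyl in place of 4-fluorophenyl on an amide-type nitrogen. Among the compounds with values here, no measured compound carries this group, so only step sizes bear on it. The remaining step is a 1.6-fold lower number from compound 1 to compound 2 (0.21 log units; within the scatter) and none of the three goes past modest. The expected change is a 1.3-fold lower number from compound 3 to compound 4 (0.11 log units; within the scatter) and nothing beyond the scatter is expected. Compound 4 is estimated at 20000 nM (expected range 9000 nM to 45000 nM).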

Compound 4, half-maximal inhibitory concentration: 11000 nM
Compound 4: middle estimate off by 1.8-fold (0.26 log units), on the high side; the range from low to high includes it.
By their numbers in this assay, from the lowest: compounds 2, 4, 1 and 3 (each within the scatter of the next, the first and the last beyond it).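

In this assay hydroxy in place of fluoro or chloro on an aromatic carbon stays within the scatter (a 1.6-fold lower number from compound 1 to compound 4 (0.21 log units; within the scatter); no change at the digits printed from compound 2 to compound 4 (within the scatter)), so the added hydrogen-bond donor and acceptor of the 3-hydroxyphenyl group leave no readable difference from either halogen. The step from the 4-fluorophenyl group is the only new one beyond the scatter, and it remains modest (a 2.4-fold lower number from compound 3 to compound 4 (0.37 log units; beyond the scatter)). Nothing at hand gives a reason for these steps. Still open, on these data alone, is whether an amine or a carboxylic acid on that aromatic carbon would also stay within the scatter of compound 4. Also open, as far as these compounds go, is whether 4-hydroxyphenyl would read with compound 3 or with compound 4.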